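This account rests on a few compounds, and the source may have more. Where it says the series, first, only, none or still open, it means among the compounds named here.

Two compounds of this series have a number in an assay on membranes from brain for binding affinity to Lysophosphatidylserine lipase ABHD12 (Mus musculus), read by fluorescence, with a stated time of 20 min; on this read-out lower numbers stand for stronger inhibition and higher numbers for weaker inhibition. Compound 1, `FC(F)(F)Oc1ccc(Oc2ccnc(N3CCC(NC(=S)Nc4cccnc4)CC3)c2Cl)c(Cl)c1`, gives 11 nM in this assay. Compound 2, `S=C(Nc1cccnc1)NC1CCN(c2cc(OC3CCCCC3)ccn2)CC1`, gives 3400 nM in this assay, the highest of the two numbers, and the gap to compound 1 lies well beyond the scatter. Compound 1 also differs from compound 2 in more than one place, so that gap cannot be laid to any single change.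

Compound 3, `S=C(Nc1cccnc1)NC1CCN(c2cc(Oc3ccccc3)ccn2)CC1`, differs from compound 2 in one place: phenyl in place of cyclohexyl on an oxygen on an aromatic ring. Compound 1 likewise carries an aromatic ring on that oxygen, so a step in the direction of a lower number seems plausible, but it is expected to be modest given how much else separates compound 1 from compound 2. The step from compound 2 to compound 3 is therefore expected to be a 2.8-fold lower number from compound 2 to compound 3 (0.45 log units; beyond the scatter), toward a lower number. Compound 3 is estimated to give 1200 nM, within a range of 300 nM to 5000 nM.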

Compound 3, half-maximal inhibitory concentration: 1900 nM
For compound 3 the middle estimate is 1.6-fold (0.20 log units) below the measured one; the range from low to high includes it.
By their numbers in this assay, from the lowest: compound 1; then compounds 3 and 2 (each within the scatter of the next).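

In this assay, phenoxy in place of cyclohexyloxy gives a 1.8-fold lower number from compound 2 to compound 3 (0.25 log units; within the scatter), so this read-out does not separate the two six-carbon rings on an oxygen on an aromatic ring. An aromatic ring on that oxygen is thus not enough on its own to set compound 3 apart from compound 2, something the earlier pair, differing in more than one place, could not show. Nothing measured here explains this result.

Compound 1 differs from compound 3 in more than one place, so the compounds shown leave open whether its chlorine atoms and trifluoromethoxy group matter singly or only together. Also open, going by these compounds, is how a methyl group, a benzyl group or a pyridyl ring would read on that oxygen.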